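The compounds below may be only part of what the source reports. "The series", "measured", "known", "first", "only" and "open" are said of these compounds alone.

Compound 3 `NC(=O)c1cccc(-c2cc(C(O)(C(F)(F)F)C(F)(F)F)cnc2N2CCN(S(=O)(=O)c3ccc(N)nc3)CC2)c1` gives 63 mL.min-1.g-1 in an ADME assay (liver) for metabolic stability, with Liver microsome (Rattus norvegicus) as the target, using microsomes and NADPH, with a stated time of 30 min, tested at 1 uM (on this read-out lower numbers stand for slow clearance and higher numbers for fast clearance), the lowest of the three numbers, though within the scatter of both neighbours. Compound 2 `CS(=O)(=O)Nc1cccc(-c2cc(C(O)(C(F)(F)F)C(F)(F)F)cnc2N2CCN(S(=O)(=O)c3ccc(N)nc3)CC2)c1` gives 81 mL.min-1.g-1 and compound 1 `Nc1ccc(S(=O)(=O)N2CCN(c3ncc(C(O)(C(F)(F)F)C(F)(F)F)cc3-c3ccccc3O)CC2)cn1` gives 125 mL.min-1.g-1. The steps at this position are all small: a 1.5-fold lower number from compound 1 to compound 2 (0.19 log units; within the scatter), a 2.0-fold lower number from compound 1 to compound 3 (0.30 log units; within the scatter) and a 1.3-fold lower number from compound 2 to compound 3 (0.11 log units; within the scatter). Compound 4 `Nc1ccc(S(=O)(=O)N2CCN(c3ncc(C(O)(C(F)(F)F)C(F)(F)F)cc3-c3ccc4[nH]ncc4c3)CC2)cn1` carries the change (1H-indazol-5-yl in place of 3-carbamoylphenyl on an aromatic carbon). The three measured steps bear on it directly, since each swaps the group at the same place, and none went beyond the scatter, so no step beyond the scatter is expected here either. For compound 4 the estimated value is 70 mL.min-1.g-1, with a range from 35 mL.min-1.g-1 to 140 mL.min-1.g-1. The implied step, a 1.1-fold higher number from compound 3 to compound 4 (0.05 log units; within the scatter), is expected to stay within the scatter.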

Compound 4, intrinsic clearance in microsomes: 88 mL.min-1.g-1
Compound 4: middle estimate off by 1.3-fold (0.10 log units), on the low side; low and high end bracket the measured number.
By their numbers in this assay, from the lowest: compounds 3, 2, 4 and 1 (each within the scatter of the next).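

In this assay, 1H-indazol-5-yl, which brings a five-membered aromatic ring with 2 hetero atoms to this aromatic carbon, gives a 1.4-fold higher number from compound 3 to compound 4 (0.15 log units; within the scatter) and a 1.1-fold higher number from compound 2 to compound 4 (0.04 log units; within the scatter) as well as a 1.4-fold lower number from compound 1 to compound 4 (0.15 log units; within the scatter) with no step beyond the scatter. Across all four compounds, this position has therefore taken both single-ring aryl groups and a fused pair of aromatic rings without a resolved difference in intrinsic clearance. Nothing available accounts for this lack of separation.

Going by these compounds, whether an aliphatic amine or a carboxylic acid at this aromatic carbon would move the number beyond the scatter remains open. The same applies to a longer chain.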